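The source may hold more compounds than are shown below. What is called first, only, known or untested is meant among the compounds shown, and "the series" means these compounds.

Measured compounds:
- compound 1, `COc1ccc2nc(N(Cc3cc(-c4ccc(SC(F)(F)F)cc4)no3)c3nc4ccc(F)cc4s3)sc2c1`: 26500 nM
- compound 2, `COc1ccc2nc(N(Cc3cc(-c4ccc(OC(F)(F)F)cc4)no3)c3nc4ccc(F)cc4s3)sc2c1`: 37100 nM
- compound 3, `COc1ccc2nc(N(Cc3cc(-c4cc(OC)c(OC)c(OC)c4)no3)c3nc4ccc(F)cc4s3)sc2c1`: 61900 nM

These three compounds share one core and differ only in the aryl group carried on the five-membered ring. In a functional assay on A549 cells (Homo sapiens) for antiproliferative activity, read by MTT assay (on this read-out higher numbers stand for weaker inhibition and lower numbers for stronger inhibition), compound 1 gives the lowest of the three numbers. Its steps to the others are small: a 1.4-fold higher number from compound 1 to compound 2 (0.15 log units; within the scatter), and a 2.3-fold higher number from compound 1 to compound 3 (0.37 log units; beyond the scatter).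

Compound 4, `COc1ccc2nc(N(Cc3cc(-c4ccccc4F)no3)c3nc4ccc(F)cc4s3)sc2c1`, has not yet been measured in this assay. It differs from compound 1 in one place: 2-fluorophenyl in place of 4-((trifluoromethyl)sulfanyl)phenyl on an aromatic carbon. The two measured steps that start from compound 1 both swap the same 4-((trifluoromethyl)sulfanyl)phenyl for another aryl group, and both give a higher number, one within the scatter and one modestly beyond it. Going by the values given here, the change to 2-fluorophenyl is of the same kind but removes more of the group, so a small rise in the number is the expectation, though nothing among the measured compounds rules out a step within the scatter. The expected step is a 1.6-fold higher number from compound 1 to compound 4 (0.20 log units; within the scatter). Compound 4 is therefore estimated at 42000 nM in this assay, with a likely range from 18000 nM to 95000 nM.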

Compound 4, half-maximal inhibitory concentration: 51800 nM
The estimate for compound 4 lay 1.2-fold (0.09 log units) below the measured number, and the stated range covers the measured number.
By their numbers in this assay, from the lowest: compounds 1, 2, 4 and 3 (each within the scatter of the next, the first and the last beyond it).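

Replacing the 4-((trifluoromethyl)sulfanyl)phenyl group with the smaller 2-fluorophenyl gives a 2.0-fold higher number from compound 1 to compound 4 (0.29 log units; within the scatter) in this assay and so shows that this position of the five-membered ring can carry a much smaller aryl group, with a single fluorine and no hydrogen-bond acceptor, without a step beyond the scatter. The comparisons with the other two aryl groups point the same way: a 1.4-fold higher number from compound 2 to compound 4 (0.14 log units; within the scatter) and a 1.2-fold lower number from compound 3 to compound 4 (0.08 log units; within the scatter) mean that 2-fluorophenyl cannot be told apart from either 4-(trifluoromethoxy)phenyl or 3,4,5-trimethoxyphenyl on these numbers. No measured property of these groups is available to explain this flat response.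

On these data alone, all four compounds carry a fluorine-bearing or methoxy-bearing phenyl ring here, so it remains open whether a plain phenyl ring, an amine or a carboxylic acid on the ring, or a longer carbon chain in place of the ring would shift the number by more than the scatter. As far as these compounds go, it is also open whether any change elsewhere on the shared core would matter more than these changes to the aryl group.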